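Changing the aryl group on the carbonyl of compound 2

The source may report more compounds than this note shows. Statements on the series, on what has been measured and on what is new or still open speak of the compounds shown alone.

Compound 1 `CN(C(=O)NC(=O)c1ccc(Cl)cc1Cl)c1nc(C(F)(F)F)c(C(=O)N/N=C/c2cccc(C(F)(F)F)c2)s1` gives 6.11 ug/mL in a functional assay on BCG823 cells (Homo sapiens) for inhibition, read by MTT assay, with a stated time of 72 h; a lower number here means a stronger inhibitor, a higher number a weaker inhibitor.
Compound 2 `CN(C(=O)NC(=O)c1ccc(Cl)cc1Cl)c1nc(C(F)(F)F)c(C(=O)N/N=C/c2ccc(C(F)(F)F)cc2)s1` gives 3.08 ug/mL in this assay.
Compound 3 `CNc1nc(C(F)(F)F)c(C(=O)N/N=C/c2cccc(C(F)(F)F)c2)s1` gives only a limit in this assay, > 100 ug/mL.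

Among the measured compounds, compound 2 and compound 1 sit within the usual scatter of each other: a 2.0-fold lower number from compound 1 to compound 2 (0.30 log units; within the scatter). Compound 3 stands at the limit of the assay, (the limit of > 100 ug/mL in this assay, at which 1 of the 3 values shown sits), so it contributes no number.

The unmeasured compound 4 `CN(C(=O)NC(=O)c1ccc(C(F)(F)F)cc1)c1nc(C(F)(F)F)c(C(=O)N/N=C/c2ccc(C(F)(F)F)cc2)s1` differs from compound 2 in one place: 4-(trifluoromethyl)phenyl in place of 2,4-dichlorophenyl on a carbonyl carbon. Among the measured compounds shown here, no measured step touches this part of the molecule. For the measured compounds named here, the only measured step, from compound 1 to compound 2, moved the trifluoromethyl group on the other aryl ring, the one attached to the carbon with a double bond to nitrogen, and it stayed within the scatter. Compound 3 lacks a number altogether and so cannot guide the estimate either.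

Going by the values given here, with no step bearing on the carbonyl aryl group, the expectation is a change no larger than the scatter, in no particular direction, and the estimated step of a 1.3-fold higher number from compound 2 to compound 4 (0.11 log units; within the scatter) reflects that. Compound 4 is therefore expected to give about 4 ug/mL, with a range from 1.5 ug/mL to 12 ug/mL.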

Compound 4, half-maximal inhibitory concentration: > 100 ug/mL
Compound 4: a limit, no number; the forecaster's own chance of this, stated with the estimate: 10%; middle value at least 25-fold (1.39 log units) from the limit.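

Among the compounds shown here, the aryl group on the carbonyl carbon matters far more in this assay than the earlier compounds could show: replacing 2,4-dichlorophenyl with 4-(trifluoromethyl)phenyl gives an at least 32-fold higher number from compound 2 to compound 4 (1.51 log units; beyond the scatter). For the compounds shown here, the only earlier step, which moved the trifluoromethyl group on the other aryl ring, was much smaller and stayed within the scatter: a 2.0-fold lower number from compound 1 to compound 2 (0.30 log units; within the scatter). Compound 4 gives > 100 ug/mL, which is a limit and not a number, and it is not the only compound at this limit: the limit of > 100 ug/mL in this assay, at which 2 of the 4 values shown sit.

With only two aryl groups compared at this position, the compounds shown leave open which part of the swap counts: whether losing the chlorines or gaining the trifluoromethyl group matters more, and how a plain phenyl, a 4-chlorophenyl or a cyclohexyl ring would behave on the same carbonyl carbon. They also leave open whether the same swap would have a similar effect when the other aryl ring carries 3-(trifluoromethyl)phenyl, as in compound 1.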